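This account rests on a few compounds, and the source may have more. Where it says the series, first, only, none or still open, it means among the compounds named here.

Measured compounds:
- compound 1, `COC(=O)c1sc2cc(Nc3cc(OC)ccc3Cl)cnc2c1N`: 25800 nM
- compound 2, `COC(=O)c1sc2cc(Nc3ccc4[nH]ccc4c3)cnc2c1N`: 17300 nM
- compound 3, `COC(=O)c1sc2cc(Nc3ccccn3)cnc2c1N`: > 150000 nM

In a functional assay on A375-C5 cells (Homo sapiens) for inhibition, read by sulforhodamine B assay, with a stated time of 48 h (on this read-out higher numbers stand for weaker inhibition of growth and lower numbers for stronger inhibition of growth), compound 1 gives 25800 nM and compound 2 gives 17300 nM. For the measured compounds named here, compound 3 stands apart from both: for compound 3 this assay reports no number but only a limit, > 150000 nM, and compound 3 is the one member of the group sitting at the limit of > 150000 nM in this assay, at which 1 of the 3 values shown sits. Going by the values given here, no pair of measured compounds differs in a single place, so no measured step is available to anchor the next change.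

Compound 4, `COC(=O)c1sc2cc(Nc3ncccn3)cnc2c1N`, differs from compound 3 by pyrimidin-2-yl in place of pyridin-2-yl on a nitrogen on an aromatic ring. With compound 3 known only as a limit, the direction of any step cannot be read from the data; the expectation for compound 4 is therefore a value no different from compound 3 beyond the usual scatter, and most probably again a limit. Compound 4 is estimated at 150000 nM, with a range from 60000 nM to 300000 nM, which amounts to an expected step of a number no higher from compound 3 to compound 4 (the limit leaves the size open).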

Compound 4, concentration for 50% growth inhibition: > 150000 nM
Compound 4: only a limit was reported (the forecaster's own chance of this, stated with the estimate: 65%); the middle value sits exactly at the limit.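

Compound 3 and compound 4 are both known only as limits, and no step can be read between them. The compounds shown leave open how far the growth inhibition of compound 3 and compound 4 lies past that limit, and whether the two differ at all.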